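This account rests on a few compounds, and the source may have more. Where it says the series, first, only, none or still open, it means among the compounds named here.

Among the measured compounds shown here, compound 2 `O=C([C@@H]1C[C@@H]1F)N1CC2CC(C1)N2` stands highest of the two numbers so far, giving 120% in an assay on CHO cells for agonist activity at Neuronal acetylcholine receptor; alpha3/alpha6/beta2/beta3 (Homo sapiens), read by FLIPR and calcium flux; a higher number here means a larger maximal response, a lower number a smaller maximal response; the nearest is compound 1 `CC(C)C(=O)N1CC2CC(C1)N2` with 45%, and the step of a number 75 percentage points higher from compound 1 to compound 2 (beyond the scatter) is large. Compound 3 `O=C([C@H]1C[C@@H]1F)N1CC2CC(C1)N2` differs from compound 2 only in configuration: the two compounds have the same atoms and bonds; at least one stereo element is drawn with a configuration in one of them and without one in the other: 1 of 4 stereo elements differ; a stereocentre at a saturated ring carbon is drawn S in compound 2 and R in compound 3. For the measured compounds named here, no measured step concerns a change of configuration; the single step from isopropyl to 2-fluorocyclopropyl does not bear on it. A change at that stereocentre could move the number either way or not beyond the scatter; a modest drop is expected, a number 25 percentage points lower from compound 2 to compound 3 (beyond the scatter). For compound 3 the estimate is 95%, with an expected range of 50% to 130%.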

Compound 3, largest response reached (Emax), in percent of the reference or control that the assay uses: 85%
Beside the measured number, compound 3's estimate is 10 percentage points above it; the range from low to high includes it.
By their numbers in this assay, from the lowest: compound 1; then compound 3; then compound 2.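

In this assay, the stereocentre on the 2-fluorocyclopropyl group matters on its own: with atoms and bonds unchanged, the result is a number 35 percentage points lower from compound 2 to compound 3 (beyond the scatter). The gain over isopropyl persists with the other drawn configuration, with a number 40 percentage points higher from compound 1 to compound 3 (beyond the scatter). The reading as a clean exchange of one configuration for the other carries a caveat: the fact that one of compounds 2 and 3 is drawn with a defined configuration and the other without, at the place where they differ

Open, on these data alone, is whether a plain cyclopropyl group, without fluorine, keeps this response. Also open, as far as these compounds go, is how a cyclobutyl group on the carbonyl carbon compares.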